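Terminal aryl variation on the shared core

This account rests on a few compounds, and the source may have more. Where it says the series, first, only, none or still open, it means among the compounds named here.

Compound 3 `COc1ccccc1-c1ccc(N(C[C@@H](N)CC(C)C)C(=O)[C@@H]2C[C@H]2c2ccccc2)cc1` gives the highest number of the three measured in a functional assay for agonist activity at G protein-coupled receptor 88 (Homo sapiens), read by HTRF and cAMP accumulation (on this read-out higher numbers stand for an effect only at larger amounts of compound and lower numbers for an effect already at smaller amounts), at 3200 nM. For comparison, compound 1 `CC(C)C[C@H](N)CN(C(=O)[C@@H]1C[C@H]1c1ccccc1)c1ccc(-c2ccsc2)cc1` gives 1200 nM in this assay, and compound 2 `CC(C)C[C@H](N)CN(C(=O)[C@@H]1C[C@H]1c1ccccc1)c1ccc(C2=CCCCCC2)cc1` gives 2100 nM. Of the steps between them, a 2.7-fold higher number from compound 1 to compound 3 (0.43 log units; beyond the scatter) is beyond the scatter, whereas a 1.8-fold higher number from compound 1 to compound 2 (0.24 log units; within the scatter) and a 1.5-fold higher number from compound 2 to compound 3 (0.18 log units; within the scatter) are within it.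

Compound 4 `CC(C)C[C@H](N)CN(C(=O)[C@@H]1C[C@H]1c1ccccc1)c1ccc(-c2ccccc2F)cc1` differs from compound 3 in one place: fluoro in place of methoxy on an aromatic carbon. Within the data shown here, no measured step swaps a single substituent on the terminal ring; each exchanges the whole group on the aromatic carbon, and together they span only a narrow band. The nearest comparisons are a 2.7-fold higher number from compound 1 to compound 3 (0.43 log units; beyond the scatter) and a 1.5-fold higher number from compound 2 to compound 3 (0.18 log units; within the scatter), both modest. A step of at most similar size, or none beyond the scatter, is therefore expected in this assay, with the direction left open. Compound 4 is expected at 2500 nM, between 1100 nM and 6000 nM, which corresponds to the expected step of a 1.3-fold lower number from compound 3 to compound 4 (0.11 log units; within the scatter).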

Compound 4, half-maximal effective concentration: 1600 nM
For compound 4 the middle estimate is 1.6-fold (0.19 log units) above the measured one; the measured number falls inside the stated range.
By their numbers in this assay, from the lowest: compounds 1, 4, 2 and 3 (each within the scatter of the next, the first and the last beyond it).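

In this assay the first change within the terminal ring itself, fluoro in place of methoxy on an aromatic carbon ortho to a large group, is read as a 2.0-fold lower number from compound 3 to compound 4 (0.30 log units; within the scatter) and so does not separate the two substituents. The steps of a 1.3-fold lower number from compound 2 to compound 4 (0.12 log units; within the scatter) and a 1.3-fold higher number from compound 1 to compound 4 (0.12 log units; within the scatter) also lie within the scatter, so 2-fluorophenyl cannot be told apart from either cyclohept-1-en-1-yl or thiophen-3-yl on this read-out. Nothing available explains these small steps.

Open, going by these compounds, is whether a hydroxyl, an amine or a carboxylic acid on this terminal ring would give a step beyond the scatter in this assay and in which direction. Also open, on these data alone, is whether the fluoro and methoxy groups would read alike on a terminal ring with a further substituent.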